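From chloro to hydroxy on compound 3

The compounds below may be only part of what the source reports. "The series", "measured", "known", "first", "only" and "open" are said of these compounds alone.

Growth results in a functional assay on A549 cells (Homo sapiens) for inhibition, read by MTT assay, with a stated time of 72 h; a higher number here means a weaker inhibitor of growth, a lower number a stronger inhibitor of growth:
- Compound 1 `O=C1CC(N2C(=O)CSC2=S)C(=O)N1c1ccc(Cl)cc1`: > 100000 nM, a limit and not a number
- Compound 2 `O=C1CC(N2C(=O)CSC2=S)C(=O)N1c1ccc(O)cc1`: > 100000 nM, a limit and not a number
- Compound 3 `O=C1CC(N2C(=O)/C(=C/C(Cl)=C/c3ccc([N+](=O)[O-])cc3)SC2=S)C(=O)N1c1ccc(Cl)cc1`: 63900 nM

For the measured compounds named here, compound 3 stands alone on this scale, since it gives the only true number, 63900 nM. The other two results sit at the limit of > 100000 nM in this assay, at which 2 of the 3 values shown sit.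

Compound 4 `O=C1CC(N2C(=O)/C(=C/C(Cl)=C/c3ccc([N+](=O)[O-])cc3)SC2=S)C(=O)N1c1ccc(O)cc1` has not yet been measured. It differs from compound 3 in one place: hydroxy in place of chloro on an aromatic carbon. This is the change from 4-chlorophenyl to 4-hydroxyphenyl.

The same exchange has been measured once, and it is a step that the two limits leave unreadable from compound 1 to compound 2. That step therefore offers neither a size nor a direction to carry over. Going by the values given here, the only anchor is compound 3 at 63900 nM, so no shift beyond the usual scatter is expected in either direction. The expected change is a 1.1-fold lower number from compound 3 to compound 4 (0.03 log units; within the scatter). Compound 4 is estimated at 60000 nM, with an expected range of 20000 nM to 100000 nM.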

Compound 4, concentration for 50% growth inhibition: 7250 nM
The estimate for compound 4 lay 8.3-fold (0.92 log units) above the measured number; the whole stated range lies above it.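

In this assay, the change from 4-chlorophenyl to 4-hydroxyphenyl now has a size and a direction that can be read, with an 8.8-fold lower number from compound 3 to compound 4 (0.95 log units; beyond the scatter) as the outcome. The group at this place, para to a large group, can therefore alter growth inhibition when the rest of the molecule is that of compound 3, although this rests on a single readable pair. Compound 1 and compound 2 could not show this, and the step between them cannot be read, because both of their results are limits and not numbers: the limit of > 100000 nM in this assay, at which 2 of the 4 values shown sit.

Going by these compounds, whether an amine or a methoxy group at the same place would match hydroxy stays open. The data do not explain the step. On these data alone, whether it would hold with other groups on the rest of compound 3 also stays open.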